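Swapping one aryl group beside a lone measured value

This account rests on a few compounds, and the source may have more. Where it says the series, first, only, none or still open, it means among the compounds named here.

For the measured compounds named here, only one number anchors this small series. Going by the values given here, in a functional assay on NCI-N87 cells (Homo sapiens) for antiproliferative activity (a higher number here means a weaker inhibitor, a lower number a stronger inhibitor), compound 1 (`CC(C)Nc1ncnn2ccc(CN3CCC(N)CC3)c12`) stands as "not determined" (no result reported) and offers nothing to compare, while compound 2 (`Cc1ccccc1Nc1ncnn2ccc(CN3CCC(N)CC3)c12`) gives 3300 nM as the sole measured value. Compound 3 (`NC1CCN(Cc2ccn3ncnc(Nc4cccc(F)c4)c23)CC1`) has 3-fluorophenyl in place of 2-methylphenyl on a nitrogen on an aromatic ring and otherwise matches compound 2. Among the compounds with values here, no measured pair shows what such a swap does in this assay so any forecast here is loose. A modest gain in strength, meaning a somewhat lower number, is expected, with a 2.2-fold lower number from compound 2 to compound 3 (0.34 log units; beyond the scatter) as the estimated step and little or no real change still possible. For compound 3 the expected half-maximal inhibitory concentration is 1500 nM with an estimated span from 350 nM to 6000 nM as the likely range.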

Compound 3, half-maximal inhibitory concentration: 280 nM
Compound 3: the middle estimate sits 5.4-fold (0.73 log units) above what was measured; the whole stated range lies above it.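

In this assay, the group on this nitrogen turns out to matter far more than the lone earlier value could show: 3-fluorophenyl in place of 2-methylphenyl gives a 12-fold lower number from compound 2 to compound 3 (1.07 log units; beyond the scatter) and so marks this position as sensitive to change. The two groups have the same count of heavy atoms and the same single six-membered aromatic ring, so a large step can arise here with no change in those counts. The swap alters both the substituent and its place on the ring, and nothing available explains the gain or assigns it to either alteration.

Still open, from the compounds shown here alone, is whether the gain tracks the fluorine or the loss of the methyl, which an unsubstituted phenyl would help separate, and how a chlorine or a methoxy group would compare. Going by these compounds, whether the gain would survive replacing the primary amine with a hydroxyl group is equally open.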